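Dropping One Ring Hydroxy From Compound 3

The compounds below may be only part of what the source reports. "The series", "measured", "known", "first", "only" and "open" are said of these compounds alone.

Of the compounds shown here, three sharing one core have been tested in a functional assay on heart right ventricle (Rattus norvegicus, strain WKY), tested at 30 uM; on this read-out higher numbers stand for a weaker effect at the one concentration tested and lower numbers for a stronger effect. Compound 1 `CCCCO[C@H](c1ccc(O)c(O)c1)[C@H](CC#Cc1ccc(O)c(O)c1)O[C@@H]1O[C@H](CO)[C@@H](O)[C@H](O)[C@H]1O` gives 88.2%, and compound 2 `CCCCO[C@@H](c1ccc(O)c(O)c1)[C@H](CC#Cc1ccc(O)c(O)c1)O[C@@H]1O[C@H](CO)[C@@H](O)[C@H](O)[C@H]1O` gives 92.2%, while compound 3 `OC[C@H]1O[C@@H](O[C@@H](CC#Cc2ccc(O)c(O)c2)[C@H](O)c2ccc(O)c(O)c2)[C@H](O)[C@@H](O)[C@@H]1O` gives 74.6%. The step of a number 4 percentage points higher from compound 1 to compound 2 (within the scatter) moves nothing beyond the scatter, the two compounds being the same except in configuration (the fact that compounds 1 and 2 differ only in the configuration as drawn). Among the measured compounds shown here, the step of a number 13.6 percentage points lower from compound 1 to compound 3 (beyond the scatter) is the only measured step that shifts the number, and it leaves compound 3 with the lowest value of the three, that is, the strongest effect seen so far.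

Compound 4 `OC[C@H]1O[C@@H](O[C@@H](CC#Cc2ccc(O)cc2)[C@H](O)c2ccc(O)c(O)c2)[C@H](O)[C@@H](O)[C@@H]1O` has not yet been measured. It differs from compound 3 in one place: hydrogen in place of hydroxy on an aromatic carbon. For the measured compounds named here, neither measured step touches a hydroxy on an aromatic ring, so no measured step speaks directly to this change, and its size is open. For compound 4 the expected step is a number 7.4 percentage points higher from compound 3 to compound 4 (within the scatter), a small move towards a weaker effect with wide uncertainty. Compound 4 is therefore estimated to give 82%, within a range from 65% to 96%.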

Compound 4, a percentage reported as activity, at one concentration (the size of the read-out at that concentration, not a potency): 94.2%
The estimate for compound 4 lay 12.2 percentage points below the measured number; the measured number falls inside the stated range.
By their numbers in this assay, from the lowest: compound 3; then compounds 1, 2 and 4 (each within the scatter of the next).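

Going from 3,4-dihydroxyphenyl to 4-hydroxyphenyl gives a number 19.6 percentage points higher from compound 3 to compound 4 (beyond the scatter) in this assay. This is the first change shown on an aromatic ring rather than on the chain, and it shows that this one hydroxy counts: without it, the stronger effect of compound 3 is lost in this pair, at the one concentration tested. The data shown give no reason why the loss of this hydroxy shifts the number.

The compounds shown leave open whether a methoxy group or an amine in this place would keep the effect of compound 3. They also leave open whether the hydroxy that remains on this ring, or the two on the other aromatic ring, count in the same way.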